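Swapping nitro for chloro on the amide-linked phenyl ring

This account rests on a few compounds, and the source may have more. Where it says the series, first, only, none or still open, it means among the compounds named here.

Measured so far:
compound 1 `O=C(Nc1ccccc1Cl)c1ccc(/N=N\c2c[nH]c3ccccc23)cc1` — 112000 nM
compound 2 `O=C(Nc1ccc([N+](=O)[O-])cc1)c1ccc(/N=N\c2c[nH]c3ccccc23)cc1` — 54500 nM

In a functional assay on MCF7 cells (Homo sapiens) for inhibition, read by MTT assay, with a stated time of 72 h (on this read-out lower numbers stand for stronger inhibition and higher numbers for weaker inhibition), compound 2 gives the lowest of the two numbers, with compound 1 next at a step of a 2.1-fold lower number from compound 1 to compound 2 (0.31 log units; beyond the scatter). Compound 3 `O=C(Nc1ccc(Cl)cc1)c1ccc(/N=N\c2c[nH]c3ccccc23)cc1` differs from compound 2 by chloro in place of nitro on an aromatic carbon. Among the measured compounds shown here, only that one step bears on it, and it changed both the group and its place, so it cannot be read off directly. A modest move in either direction seems as likely as none, so compound 3 is expected near 80000 nM, between 30000 nM and 200000 nM, a step of a 1.5-fold higher number from compound 2 to compound 3 (0.17 log units; within the scatter).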

Compound 3, half-maximal inhibitory concentration: 107000 nM
Compound 3: middle estimate off by 1.3-fold (0.13 log units), on the low side; low and high end bracket the measured number.
By their numbers in this assay, from the lowest: compounds 2, 3 and 1 (each within the scatter of the next, the first and the last beyond it).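

Compound 3 separates the earlier step, which changed group and place together. Chloro in place of nitro gives a 2.0-fold higher number from compound 2 to compound 3 (0.29 log units; within the scatter) and 4-chlorophenyl in place of 2-chlorophenyl gives a 1.0-fold lower number from compound 1 to compound 3 (0.02 log units; within the scatter), so in this assay each single change stays within the scatter, although the two combined went beyond it. No measurement at hand accounts for these numbers.

Going by these compounds, whether an amine or a carboxylic acid in this place would move the number beyond the scatter remains open. So does the result for a plain phenyl ring carrying no added group.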